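Benzimidazolyl in place of the aryl hydrazone arm

This account rests on a few compounds, and the source may have more. Where it says the series, first, only, none or still open, it means among the compounds named here.

For the measured compounds named here, in a functional assay, read by spectrophotometry, with a stated time of 3 min (on this read-out higher numbers stand for weaker inhibition and lower numbers for stronger inhibition), compound 3 `O=c1cc(/C=N\Nc2ccccc2)c2ccc(OCc3ccccc3)cc2o1` gives 13200 nM, the highest of the three numbers so far; its gap to compound 1 lies within the scatter, that to compound 2 beyond it. Compound 1 `O=c1cc(/C=N\Nc2ccc([N+](=O)[O-])cc2)c2ccc(OCc3ccccc3)cc2o1` gives 9510 nM in this assay, and compound 2 `O=c1cc(/C=N\Nc2ccc([N+](=O)[O-])cc2[N+](=O)[O-])c2ccc(OCc3ccccc3)cc2o1` gives 6490 nM. The measured steps are a 1.5-fold lower number from compound 1 to compound 2 (0.17 log units; within the scatter) and a 1.4-fold higher number from compound 1 to compound 3 (0.14 log units; within the scatter); both concern only a nitro on the six-membered ring of the arm. Compound 4 `O=c1cc(-c2nc3ccccc3[nH]2)c2ccc(OCc3ccccc3)cc2o1` replaces that arm: a group of 9 heavy atoms (7 carbon, 2 nitrogen; one five-membered aromatic ring with 2 hetero atoms, one six-membered aromatic ring of carbon only) in place of a group of 9 heavy atoms (7 carbon, 2 nitrogen; one six-membered aromatic ring of carbon only), on an aromatic carbon. Neither measured step bears on this change, so no direction beyond the scatter is expected and the estimate rests near compound 3 with a wide range. In this assay compound 4 is expected to give 12000 nM, in a range from 3000 nM to 50000 nM. The step expected from this is a 1.1-fold lower number from compound 3 to compound 4 (0.04 log units; within the scatter).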

Compound 4, half-maximal inhibitory concentration: "not active" (no number reported)
Compound 4 has no reported number here, so the estimate cannot be set against anything.
By their numbers in this assay, from the lowest: compounds 2, 1 and 3 (each within the scatter of the next, the first and the last beyond it).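

In this assay, for the compounds shown here, compound 4 is reported as "not active" with no number, so no step from compound 3 can be read. No supporting data bear on this result. Still open, as far as these compounds go, is how far 1H-benzimidazol-2-yl stands from the arm of compound 3 in numbers.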